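Replacing the trifluorophenyl with benzyl: what to expect

The compounds below may be only part of what the source reports. "The series", "measured", "known", "first", "only" and "open" are said of these compounds alone.

Compound 1 `Cc1ccc(S(=O)(=O)/N=C(/CCNC2=CC(=O)c3ccccc3C2=O)Nc2ccc(F)cc2)cc1` gives 12200 nM in a functional assay on DU-145 cells (Homo sapiens) for cytotoxicity, read by MTT assay, with a stated time of 48 h; a lower number here means a stronger inhibitor, a higher number a weaker inhibitor.
Compound 2 `Cc1ccc(S(=O)(=O)/N=C(/CCNC2=CC(=O)c3ccccc3C2=O)Nc2ccc(F)c(F)c2)cc1` gives 12900 nM in this assay.
Compound 3 `Cc1ccc(S(=O)(=O)/N=C(/CCNC2=CC(=O)c3ccccc3C2=O)Nc2cc(F)c(F)c(F)c2)cc1` gives 12600 nM in this assay.

Compound 3 stands with compounds 1 and 2 in a tight cluster; the steps of a 1.0-fold higher number from compound 1 to compound 3 (0.01 log units; within the scatter), a 1.0-fold lower number from compound 2 to compound 3 (0.01 log units; within the scatter) and a 1.1-fold higher number from compound 1 to compound 2 (0.02 log units; within the scatter) all stay within the scatter, so the three cannot be ranked. Compound 4 `Cc1ccc(S(=O)(=O)/N=C(/CCNC2=CC(=O)c3ccccc3C2=O)NCc2ccccc2)cc1` introduces a different kind of change: benzyl in place of 3,4,5-trifluorophenyl on an amine nitrogen. Going by the values given here, none of the measured steps touches this change; they only add fluorine to the aryl ring, and none moved the number. There is thus no measured basis for expecting a shift in this assay. Compound 4 is expected to give about 12500 nM, within a range of 5000 nM to 32000 nM. This estimated step, a 1.0-fold lower number from compound 3 to compound 4 (0.00 log units; within the scatter), sits within the scatter.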

Compound 4, half-maximal inhibitory concentration: 9120 nM
For compound 4 the middle estimate is 1.4-fold (0.14 log units) above the measured one, and the stated range covers the measured number.
By their numbers in this assay, from the lowest: compounds 4, 1, 3 and 2 (each within the scatter of the next).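

In this assay the benzyl change is the only one shown that replaces the whole group on this amine nitrogen rather than adding fluorine to it. All three steps stay within the scatter (a 1.4-fold lower number from compound 3 to compound 4 (0.14 log units; within the scatter)) (a 1.4-fold lower number from compound 2 to compound 4 (0.15 log units; within the scatter)) (a 1.3-fold lower number from compound 1 to compound 4 (0.13 log units; within the scatter)). Going by these compounds alone, this position therefore accepts benzyl as well as the fluorinated phenyl groups, and no compound can be ranked above another. No evidence is available to explain this result. The compounds shown leave open whether a longer chain such as 2-phenylethyl, or a group carrying a carboxylic acid or an amine, would move the number at this nitrogen.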